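A few compounds are considered here, and "the series" means these few. Any claim that something is new, unique, unknown or untested is made for them only; others in the source may bear on it.

Compound 1 `COc1cc(OC)c2c(=O)cc(-c3ccc(OCCCN(C)C)cc3)oc2c1` gives the higher of the two numbers measured in a functional assay (Homo sapiens) for antiproliferative activity, read by resazurin assay, with a stated time of 48 h, tested at 5 uM (a lower number here means a weaker effect, a higher number a stronger effect of the compound at the concentration tested), namely 36%. Going by the values given here, the only other measured compound, compound 2 `COc1cc(OC)c2c(=O)cc(-c3ccc(OCC(O)CN4CCCC4)cc3)oc2c1`, gives 21% in this assay, and that comparison is the one measured step: a number 15 percentage points lower from compound 1 to compound 2 (beyond the scatter). Compound 3 `COc1cc(OC)c2c(=O)cc(-c3ccc(NCCN(C)C)cc3)oc2c1` has not yet been measured. It differs from compound 1 at a single point: (2-(dimethylamino)ethyl)amino in place of 3-(dimethylamino)propoxy on an aromatic carbon. The measured step from compound 1 to compound 2 altered the far end of the chain that hangs from the oxygen on the aromatic ring, whereas the change to compound 3 replaces that whole 3-(dimethylamino)propoxy group with a (2-(dimethylamino)ethyl)amino group on the same aromatic carbon. Among the compounds with values here, no measured pair shows what such a replacement does, so the one known step gives only a loose guide to the size of change that this kind of edit can produce. On that basis the step of a number 4 percentage points lower from compound 1 to compound 3 (within the scatter) is expected to stay within the usual scatter. Compound 3 is therefore estimated to give 32% in this assay, with a range from 15% to 50%.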

Compound 3, a percentage reported as inhibition, at one concentration (the size of the read-out at that concentration, not a potency): 30%
For compound 3 the middle estimate is 2 percentage points above the measured one; the range from low to high includes it.
By their numbers in this assay, from the lowest: compounds 2, 3 and 1 (each within the scatter of the next, the first and the last beyond it).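

Compound 3 gives the first view of replacing the entire side chain on this aromatic carbon, para to a large group, rather than only its far end, and in this assay putting (2-(dimethylamino)ethyl)amino in place of 3-(dimethylamino)propoxy gives a number 6 percentage points lower from compound 1 to compound 3 (within the scatter), so the new chain, with its nitrogen link, cannot be told apart from the original chain with its oxygen link. Compound 3 also shows a number 9 percentage points higher from compound 2 to compound 3 (within the scatter), which means that although compound 1 and compound 2 stand apart, compound 3 cannot be grouped with either of them alone. No accompanying measurement offers an explanation for these readings.

This single swap changes both the linking atom and the chain, so a 2-(dimethylamino)ethoxy chain or a 3-(dimethylamino)propylamino chain would be needed to separate those two changes. Also open, going by these compounds, is how a morpholine at the chain end would read in this assay, and whether the picture seen at this one concentration would hold across a full range of concentrations.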